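The source may hold more compounds than are shown below. What is called first, only, known or untested is meant among the compounds shown, and "the series" means these compounds.

Measured in a physicochemical assay for solubility, read by HPLC, with a stated time of 4 h, at pH 3; a lower number here means a less soluble compound, a higher number a more soluble compound:
compound 1 `COc1ccc2c(c1)c(CC(=O)OCOC(=O)C(C)(C)C)c(C)n2C(=O)c1ccc(Cl)cc1` gives 0.084 ug/mL
compound 2 `COc1ccc2c(c1)c(CC(=O)OCOC(=O)OC(C)C)c(C)n2C(=O)c1ccc(Cl)cc1` gives 0.119 ug/mL
compound 3 `COc1ccc2c(c1)c(CC(=O)OCCOC(C)=O)c(C)n2C(=O)c1ccc(Cl)cc1` gives 0.111 ug/mL

Compound 3 holds the second highest of the three numbers, but this rank carries little weight: the step of a 1.1-fold lower number from compound 2 to compound 3 (0.03 log units; within the scatter) and the step of a 1.3-fold higher number from compound 1 to compound 3 (0.12 log units; within the scatter) both lie within the scatter, so the three compounds cannot be told apart on solubility here. The remaining step, a 1.4-fold higher number from compound 1 to compound 2 (0.15 log units; within the scatter), is also within the scatter.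

Compound 4 `COc1ccc2c(c1)c(CC(=O)OCc1oc(=O)oc1C)c(C)n2C(=O)c1ccc(Cl)cc1` differs from compound 3 by a group of 7 heavy atoms (4 carbon, 3 oxygen; one five-membered aromatic ring with 2 hetero atoms) in place of a group of 5 heavy atoms (3 carbon, 2 oxygen; no ring), on a saturated chain carbon bound to an oxygen next to a carbonyl group. All three measured steps bear on this change, since each of them exchanges one group for another at this same saturated chain carbon, and none of them moved the number beyond the scatter. A fourth exchange at the same place is therefore expected to behave alike: the step of a 1.1-fold lower number from compound 3 to compound 4 (0.05 log units; within the scatter) is expected to be small and without a clear direction, though the entering group is larger than any that has been tried, so the range is set a little wider than the measured spread.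

Compound 4 is expected to give about 0.1 ug/mL in this assay, with a range from 0.04 ug/mL to 0.25 ug/mL.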

Compound 4, solubility: 0.0638 ug/mL
Beside the measured number, compound 4's estimate is 1.6-fold (0.20 log units) above it, and the stated range covers the measured number.
By their numbers in this assay, from the lowest: compounds 4, 1, 3 and 2 (each within the scatter of the next).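

In this assay, the ring-bearing group at this saturated chain carbon bound to an oxygen next to a carbonyl group stays within the scatter of all three open-chain compounds: a 1.7-fold lower number from compound 3 to compound 4 (0.24 log units; within the scatter), a 1.9-fold lower number from compound 2 to compound 4 (0.27 log units; within the scatter) and a 1.3-fold lower number from compound 1 to compound 4 (0.12 log units; within the scatter). The earlier steps shown here had only exchanged groups without a ring, whereas these show that one five-membered aromatic ring with 2 hetero atoms can enter at this place without a step beyond the scatter, so the four compounds cannot be told apart on solubility. No supporting measurement bears on why the numbers fall as they do.

Going by these compounds, all four groups at this place contain only carbon and oxygen and carry no net charge, so it remains open whether an amine or a carboxylic acid here would move the number beyond the scatter. Also open, on these data alone, is whether a longer chain at this carbon, or a change elsewhere on the shared core, would separate compounds that these four values leave together.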